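The compounds below may be only part of what the source reports. "The series", "measured", "known", "first", "only" and "open" are said of these compounds alone.

Working notes on the series.

Four compounds share one core; the difference between the core of compound 1 and the core of compound 3 is not broken down here. Compound 1, `C=C1CC[C@H]2[C@@](C)(CCC(=O)N[C@@]2(C)COC(=O)c2ccc([N+](=O)[O-])cc2)[C@@H]1/C=C/C1=CCOC1=O`, carries a 4-nitrophenyl on a carbonyl carbon. Compound 2, `C=C1CC[C@H]2[C@@](C)(CCC(=O)N[C@@]2(C)COC(=O)[C@H](N)CC(C)C)[C@@H]1/C=C/C1=CCOC1=O`, differs from it by 1-amino-3-methylbutyl in place of 4-nitrophenyl on a carbonyl carbon. Compound 3, `C=C1CC[C@H]2[C@@](C)(CC[C@@H](OC(=O)c3ccc([N+](=O)[O-])cc3)[C@@]2(C)NC=O)[C@@H]1/C=C/C1=CCOC1=O`, is the second core with the same 4-nitrophenyl ester, and compound 4, `C=C1CC[C@H]2[C@@](C)(CC[C@@H](OC(=O)[C@H](N)CC(C)C)[C@@]2(C)NC=O)[C@@H]1/C=C/C1=CCOC1=O`, is the not yet measured analogue that differs from compound 3 by 1-amino-3-methylbutyl in place of 4-nitrophenyl on a carbonyl carbon; the two place lines read the same word for word, so this is the same kind of change as that from compound 1 to compound 2.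

In an assay for inhibition of hexokinase-2 (Homo sapiens), read by coupled enzyme assay, with a stated time of 10 min, in the presence of a further agent that is not named here (a lower number here means a stronger inhibitor, a higher number a weaker inhibitor), compound 1 gives only a limit, > 50000 nM. In this assay compound 2 likewise gives only a limit, > 50000 nM. In this assay compound 3 also gives only a limit, > 50000 nM. Hence a step that the two limits leave unreadable from compound 1 to compound 2; the size of that step cannot be read, because of the limit of > 50000 nM in this assay, at which 3 of the 3 values shown sit.

Among the measured compounds shown here, for compound 4 in this assay the expectation rests on the same footing: compound 3 sits at the limit > 50000 nM and the one measured instance of this change, on the core of compound 1, gave no readable step. The expected step is a step that the limit leaves unreadable from compound 3 to compound 4, meaning no measurable change is anticipated. The estimate for compound 4 in this assay is therefore 80000 nM, between 30000 nM and 300000 nM, most likely reported again only as a limit.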

Compound 4, half-maximal inhibitory concentration: > 50000 nM
Compound 4 gave a limit, no number (the forecaster's own chance of this, stated with the estimate: 85%); the middle value does not contradict the limit.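

In this assay compound 4 gives only a limit, > 50000 nM. No new step can be read between compound 3 and compound 4, because of this: the limit of > 50000 nM in this assay, at which 4 of the 4 values shown sit. The compounds shown leave open whether any of them has an inhibition in this assay that can be stated as a number, and so how 4-nitrophenyl and 1-amino-3-methylbutyl compare on either core.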